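The source may report more compounds than this note shows. Statements on the series, on what has been measured and on what is new or still open speak of the compounds shown alone.

Compounds measured so far:
compound 1 `COc1ccc(S(=O)(=O)N2CCc3cccc(NC(=O)c4ccc(C#N)cc4)c32)cc1`: 105 nM
compound 2 `COc1ccc(S(=O)(=O)N2CCc3cccc(NC(=O)c4cccs4)c32)cc1`: 47 nM

Among the measured compounds shown here, in a functional assay on KB cells (Homo sapiens) for cytotoxicity (a lower number here means a stronger inhibitor, a higher number a weaker inhibitor), compound 2 gives 47 nM, the lower of the two numbers measured; compound 1, the only other measured compound, gives 105 nM, and the step from it is a 2.2-fold lower number from compound 1 to compound 2 (0.35 log units; beyond the scatter). Compound 3 `COc1ccc(S(=O)(=O)N2CCc3cccc(NC(C)=O)c32)cc1` differs from compound 2 as follows.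

methyl in place of thiophen-2-yl on a carbonyl carbon

For the measured compounds named here, the one measured step, a 2.2-fold lower number from compound 1 to compound 2 (0.35 log units; beyond the scatter), swaps one ring for another on the carbonyl carbon and so speaks only indirectly to the present change, in which the ring is removed altogether and only a methyl remains. Going by the values given here, with no measured step covering such a removal, the expectation rests on the observation that both measured compounds carry a ring at this position and both are potent. Compound 3 is therefore expected to give a weaker result, estimated at 400 nM (range 100 nM to 2000 nM), a step of an 8.5-fold higher number from compound 2 to compound 3 (0.93 log units; beyond the scatter) beyond the scatter.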

Compound 3, half-maximal inhibitory concentration: 89 nM
Compound 3: middle estimate off by 4.5-fold (0.65 log units), on the high side; measured number outside the range, below it.
By their numbers in this assay, from the lowest: compounds 2, 3 and 1 (each within the scatter of the next, the first and the last beyond it).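

In this assay, the methyl compound could not be separated from either ring-bearing compound, with a 1.9-fold higher number from compound 2 to compound 3 (0.28 log units; within the scatter) for the loss of thiophen-2-yl and a 1.2-fold lower number from compound 1 to compound 3 (0.07 log units; within the scatter) for the loss of 4-cyanophenyl. At this position, on a carbonyl carbon bonded to an amide-type nitrogen, a group of 1 heavy atom with no ring therefore reads the same, within the scatter, as the thiophen-2-yl of 5 heavy atoms, so a ring here is not required for a number of this size. No evidence is available to explain this result.

The compounds shown leave open what a longer chain such as propyl, a saturated ring such as cyclohexyl or a carboxylic acid would give on this carbonyl carbon. They also leave open how a plain amine in place of the acetamido would compare.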